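From Isobutyl to Phenethyl in a Guinea Pig Series

The source may report more compounds than this note shows. Statements on the series, on what has been measured and on what is new or still open speak of the compounds shown alone.

- Compound 1 `C/C=C/C(NC(=O)c1ccc(C(=N)N)cc1)C(C)(C)C(=O)N1CCC(CC(=O)O)CC1` gives 0.933 h
- Compound 2 `CCCCC(NC(=O)c1ccc(C(=N)N)cc1)C(C)(C)C(=O)N1CCC(CC(=O)O)CC1` gives 1.03 h
- Compound 3 `CC(C)CC(NC(=O)c1ccc(C(=N)N)cc1)C(C)(C)C(=O)N1CCC(CC(=O)O)CC1` gives 0.917 h
- Compound 4 `CC(C)(C(=O)N1CCC(CC(=O)O)CC1)C(CCc1ccccc1)NC(=O)c1ccc(C(=N)N)cc1` still awaits measurement

All three numbers come from an in vivo ADME assay on the whole organism (Cavia porcellus) (on this read-out lower numbers stand for a shorter-lived compound and higher numbers for a longer-lived compound), and lie within the usual scatter of one another, so compound 3 (0.917 h) stands level with compound 1 and compound 2. Compound 4 carries benzyl in place of isopropyl on a saturated chain carbon, two bonds along the chain from an amide-type nitrogen.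

The closest measured change sits at that same place, where isopropyl replaced propyl, and it stayed within the scatter (a 1.1-fold lower number from compound 2 to compound 3 (0.05 log units; within the scatter)). Putting butyl (a 1.1-fold higher number from compound 1 to compound 2 (0.04 log units; within the scatter)) or isobutyl (a 1.0-fold lower number from compound 1 to compound 3 (0.01 log units; within the scatter)) in place of prop-1-en-1-yl also stayed within it. None of these compounds carries a ring at this place, so the new group goes beyond what has been measured, and the range is set wide. Even so, no step beyond the scatter is expected in this assay, and the estimated step is small (a 1.0-fold higher number from compound 3 to compound 4 (0.02 log units; within the scatter)). Compound 4 is therefore expected at 0.95 h (estimated range 0.55 h to 1.6 h).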

Compound 4, half-life: 0.767 h
Beside the measured number, compound 4's estimate is 1.2-fold (0.09 log units) above it; measured number inside the range.
By their numbers in this assay, from the lowest: compounds 4, 3, 1 and 2 (each within the scatter of the next).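

The first ring at this place, the six-membered aromatic ring of carbon only that comes with benzyl in place of isopropyl, leaves this assay within the scatter (a 1.2-fold lower number from compound 3 to compound 4 (0.08 log units; within the scatter)). Compared with the two other open-chain compounds, compound 4 also stays within the scatter (a 1.3-fold lower number from compound 2 to compound 4 (0.13 log units; within the scatter); a 1.2-fold lower number from compound 1 to compound 4 (0.09 log units; within the scatter)), so all four compounds stand level on half-life, even though the entering group has 7 heavy atoms where the leaving one has 3. Nothing in the available data explains why the ring and the added size leave the half-life level.

All the groups shown at this place are made of carbon and hydrogen alone, so it remains open whether an amine, a hydroxyl or a carboxylic acid on this chain would bring a step beyond the scatter. A chain longer than phenethyl, or a phenyl ring carrying a fluorine or a methoxy group, also remains untested among these compounds, and a single ring at this place cannot show how far the level half-life extends.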